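Sulfonyl aryl swap across two fluoroquinoline cores

The compounds below may be only part of what the source reports. "The series", "measured", "known", "first", "only" and "open" are said of these compounds alone.

Measured compounds:
Compound 1 `COc1ccc(-c2c(S(=O)(=O)c3cccc(C#N)c3)cnc3cc(F)ccc23)cc1`: 0.92 mL/min
Compound 2 `COc1ccc(S(=O)(=O)c2cnc3c(F)cccc3c2-c2cccc(Cl)c2)cc1`: 2.75 mL/min
Compound 3 `COc1ccc(-c2c(S(=O)(=O)c3ccc(OC)cc3)cnc3cc(F)ccc23)cc1`: 1.18 mL/min

The study tracks three compounds in an ADME assay on microsomes from liver (Homo sapiens) for metabolic stability, tested at 2.5 uM (on this read-out lower numbers stand for slow clearance and higher numbers for fast clearance), and asks what a fourth, compound 4 `N#Cc1cccc(S(=O)(=O)c2cnc3c(F)cccc3c2-c2cccc(Cl)c2)c1`, is likely to show. Compound 3 carries a 4-methoxyphenyl on its sulfonyl sulfur; compound 1 differs from it by 3-cyanophenyl in place of 4-methoxyphenyl on a sulfonyl sulfur, and in this assay this gave a 1.3-fold lower number from compound 3 to compound 1 (0.11 log units; within the scatter). Compound 2 sits on a different core, and the difference between the two cores is not broken down here; its number in this assay is the highest of the three, beyond the scatter from both compound 3 and compound 1.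

Compound 4 is related to compound 2 by 3-cyanophenyl in place of 4-methoxyphenyl on a sulfonyl sulfur, the same change as that from compound 3 to compound 1. On the evidence of that single earlier step, the author expects compound 4 to remain close to compound 2, with an estimated step of a 1.2-fold lower number from compound 2 to compound 4 (0.08 log units; within the scatter) in this assay, because the move from compound 3 to compound 1 gave only a 1.3-fold lower number from compound 3 to compound 1 (0.11 log units; within the scatter). Compound 4 is therefore estimated at 2.3 mL/min in this assay, plausibly between 1.3 mL/min and 4 mL/min.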

Compound 4, intrinsic clearance in a liver preparation (reported as CLH), per the amount of preparation that the assay uses: 1.11 mL/min
Compound 4: middle estimate off by 2.1-fold (0.32 log units), on the high side; measured number below the stated range.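

In this assay, 3-cyanophenyl in place of 4-methoxyphenyl on a sulfonyl sulfur gave a 2.5-fold lower number from compound 2 to compound 4 (0.39 log units; beyond the scatter). This step is beyond the scatter on its own, whereas the earlier one was not, yet the two cannot be told apart, so nothing here indicates that the core alters the outcome of the change: the same change on two cores in this assay, a 1.3-fold lower number (0.11 log units; within the scatter) from compound 3 to compound 1 and a 2.5-fold lower number (0.39 log units; beyond the scatter) from compound 2 to compound 4, 1.9-fold (0.29 log units) apart, within the scatter of two such steps This does not show that the step has the same size on both cores, and two pairs of compounds give no general rule for the series.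

The compounds shown leave open how other groups on the sulfonyl sulfur, such as an amine or a carboxylic acid, would read in this assay on either core. They also leave open which of the differences between the two cores accounts for the gap between their compounds, as the cores differ in more than one place.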